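Taking the methyl off compound 2

The source may hold more compounds than are shown below. What is called first, only, known or untested is meant among the compounds shown, and "the series" means these compounds.

Of the compounds shown here, three sharing one core have been measured in a functional assay on MCF7 cells (Homo sapiens) for inhibition, read by sulforhodamine B assay, with a stated time of 72 h; a higher number here means a weaker inhibitor of growth, a lower number a stronger inhibitor of growth. Compound 1 `CCOC(=O)/C=C/c1ccncc1-c1ccc2c(ccn2C)c1` gives 8670 nM and compound 3 `CNC(=O)/C=C/c1ccncc1-c1ccc2c(ccn2C)c1` gives 7120 nM, two values within the scatter of each other. Compound 2 `Cn1ccc2cc(-c3cnccc3/C=C/C(=O)O)ccc21` reads > 10000 nM, which is a limit of this assay and not a number. Compound 2 thus stands at the limit of > 10000 nM in this assay, at which 1 of the 3 values shown sits.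

Compound 4 `O=C(O)/C=C/c1ccncc1-c1ccc2[nH]ccc2c1` carries hydrogen in place of methyl on an aromatic nitrogen. Among the compounds with values here, no measured step touches that nitrogen. All three change the group on the carbonyl carbon, so they bear on this change only indirectly. Two of them are an at least 1.1-fold higher number from compound 1 to compound 2 (0.06 log units; that floor lies within the scatter) and a 1.2-fold lower number from compound 1 to compound 3 (0.09 log units; within the scatter). Judging by an at least 1.4-fold lower number from compound 2 to compound 3 (0.14 log units; that floor lies within the scatter), no step beyond the scatter is expected in this assay, in either direction. The estimate means a step that the limit leaves unreadable from compound 2 to compound 4, which is an expected change within the scatter. Compound 4 is estimated at 12000 nM, with an expected range from 6000 nM to 25000 nM, and it may again be reported only as a limit.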

Compound 4, concentration for 50% growth inhibition: > 10000 nM
Compound 4 gave a limit, no number (the forecaster's own chance of this, stated with the estimate: 65%); the middle value does not contradict the limit.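

In this assay compound 2 and compound 4 both give only a limit and not a number, so no step can be read between them: the limit of > 10000 nM in this assay, at which 2 of the 4 values shown sit.

The compounds shown leave open what hydrogen in place of methyl on an aromatic nitrogen does to growth inhibition in this assay.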